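A single methyl on the shared core, and its expected effect

The source may hold more compounds than are shown below. What is called first, only, known or untested is meant among the compounds shown, and "the series" means these compounds.

Compound 1, `COCn1c(CC(COCc2ccccc2)COCc2ccccc2)cc(=O)[nH]c1=O`, gives > 100000 nM in a functional assay on HeLa cells (Homo sapiens) for antiproliferative activity, read by MTT assay, with a stated time of 72 h (a lower number here means a stronger inhibitor, a higher number a weaker inhibitor), which is a limit of the measurement rather than a number.
Compound 2, `COCn1c(CC(COCc2ccccc2)COCc2ccccc2)c(C)c(=O)[nH]c1=O`, gives 29700 nM in this assay.
Compound 3, `O=c1cc(CC(O)COCc2ccccc2)[nH]c(=O)[nH]1`, gives > 100000 nM in this assay, again a limit of the measurement rather than a number.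

Compound 2 differs from compound 1 by one change: methyl in place of hydrogen on an aromatic carbon. That change made an at least 3.3-fold lower number from compound 1 to compound 2 (0.52 log units; beyond the scatter), a step that is known only as a lower bound since compound 1 sits at a limit.

Compound 4, `Cc1c(CC(O)COCc2ccccc2)[nH]c(=O)[nH]c1=O`, is not yet measured. It differs from compound 3 by methyl in place of hydrogen on an aromatic carbon. Among the compounds with values here, this is the same kind of change as the one from compound 1 to compound 2, though the surroundings are not identical: around compound 2 the entering methyl is also meta to a methoxymethyl group, whereas the core of compound 3 carries no such group at that place. How the core of compound 3 differs from the core of compound 1 is not broken down here.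

As far as these compounds go, because compound 3 sits at the limit of > 100000 nM in this assay, at which 2 of the 3 values shown sit, its true value is unknown, and the expected step can only be added to a bound. For compound 4 a step like the earlier one is expected, roughly an at least 2.5-fold lower number from compound 3 to compound 4 (0.39 log units; beyond the scatter) in this assay. Compound 4 is therefore estimated at 40000 nM, with a plausible range from 12000 nM to 150000 nM, and a real chance that only a limit is reported again.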

Compound 4, half-maximal inhibitory concentration: > 100000 nM
Compound 4 gave a limit, no number (the forecaster's own chance of this, stated with the estimate: 40%); at least 2.5-fold (0.39 log units) between middle value and limit.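

Compound 3 and compound 4 both end at a limit of the measurement rather than a number, so in this assay the size of the step between them cannot be read. Most of the values shown now share that limit: the limit of > 100000 nM in this assay, at which 3 of the 4 values shown sit. The compounds shown leave open whether the methyl lowers the number on the core of compound 3 as it did on the core of compound 1.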